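Pyrrolidin-1-yl in place of piperidin-1-yl: working notes

The source may report more compounds than this note shows. Statements on the series, on what has been measured and on what is new or still open speak of the compounds shown alone.

Measured in a functional assay on A549 cells (Homo sapiens) for cytotoxicity, read by MTT assay, with a stated time of 48 h (on this read-out higher numbers stand for weaker inhibition and lower numbers for stronger inhibition), so far
compound 1 `COc1c(OCCCCN2CCNCC2)cc(O)c2c(=O)cc(-c3ccccc3)oc12` gives 1740 nM
compound 2 `COc1c(OCc2ncc(C)o2)cc(O)c2c(=O)cc(-c3ccccc3)oc12` gives > 100000 nM as a limit of the assay
compound 3 `COc1c(OCCCCN2CCCCC2)cc(O)c2c(=O)cc(-c3ccccc3)oc12` gives 1150 nM

Compound 3 at 1150 nM has one numeric neighbour, compound 1, and a 1.5-fold lower number from compound 1 to compound 3 (0.18 log units; within the scatter) stays level. Compound 4 `COc1c(OCCCCN2CCCC2)cc(O)c2c(=O)cc(-c3ccccc3)oc12` carries the change pyrrolidin-1-yl in place of piperidin-1-yl on a saturated chain carbon, four bonds along the chain from an oxygen on an aromatic ring with pyrrolidin-1-yl in place of piperidin-1-yl, on a saturated chain carbon, four bonds along the chain from an oxygen on an aromatic ring. That ring exchange at the same place is the nearest guide. The steps of an at least 57-fold higher number from compound 1 to compound 2 (1.75 log units; beyond the scatter) and an at least 86-fold lower number from compound 2 to compound 3 (1.93 log units; beyond the scatter) are large, but they replace the whole group on the chain and rest on the limit of > 100000 nM in this assay, at which 1 of the 3 values shown sits, so they guide little here. In this assay the estimated step is a 1.1-fold higher number from compound 3 to compound 4 (0.05 log units; within the scatter) and none beyond the scatter is expected. Compound 4 is expected at 1300 nM with an estimated range from 600 nM to 3000 nM in this read-out.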

Compound 4, half-maximal inhibitory concentration: 1530 nM
Beside the measured number, compound 4's estimate is 1.2-fold (0.07 log units) below it; the range from low to high includes it.
By their numbers in this assay, from the lowest: compounds 3, 4 and 1 (each within the scatter of the next). At a limit, above all of these: compound 2.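

In this assay, the five-membered pyrrolidin-1-yl ring in place of the six-membered piperidin-1-yl ring leaves the read-out level, a 1.3-fold higher number from compound 3 to compound 4 (0.12 log units; within the scatter), and pyrrolidin-1-yl in place of piperazin-1-yl does the same, a 1.1-fold lower number from compound 1 to compound 4 (0.06 log units; within the scatter). Compounds 1, 3 and 4 thus stay level across all three saturated rings at this place. The large step, an at least 65-fold lower number from compound 2 to compound 4 (1.81 log units; beyond the scatter), again exchanges the whole group on the chain and rests on a limit for compound 2: the limit of > 100000 nM in this assay, at which 1 of the 4 values shown sits.

Open, as far as these compounds go, is whether morpholin-4-yl or an open-chain dimethylamino group at the chain end, or a shorter or longer chain, would stay at this level.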